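Adding a methyl at the chain carbon of compound 2

This account rests on a few compounds, and the source may have more. Where it says the series, first, only, none or still open, it means among the compounds named here.

Compounds measured so far:
compound 1 `CC(C)(C)c1ccc(CNC(=S)NC(C)(C)c2ccc(NS(C)(=O)=O)c(F)c2)cc1` with 980 nM
compound 2 `COc1cc(C(C)NC(=S)NCc2ccc(C(C)(C)C)cc2)ccc1NS(C)(=O)=O` with 28.6 nM

Of the compounds shown here, two have been measured in a functional assay on CHO cells for antagonist activity at transient receptor potential cation channel subfamily V member 1 (Rattus norvegicus); a lower number here means a stronger inhibitor, a higher number a weaker inhibitor. Compound 1 `CC(C)(C)c1ccc(CNC(=S)NC(C)(C)c2ccc(NS(C)(=O)=O)c(F)c2)cc1` gives 980 nM in this assay. Compound 2 `COc1cc(C(C)NC(=S)NCc2ccc(C(C)(C)C)cc2)ccc1NS(C)(=O)=O` gives 28.6 nM in this assay, the lowest of the two numbers; compound 1 stands a long way above it, well beyond the scatter. Compound 3 `COc1cc(C(C)(C)NC(=S)NCc2ccc(C(C)(C)C)cc2)ccc1NS(C)(=O)=O` has not yet been measured. It differs from compound 2 in one place: methyl in place of hydrogen on a saturated chain carbon bound to an amide-type nitrogen, an aromatic carbon and a saturated chain carbon. Going by the values given here, no step between two measured compounds covers this change on its own, since compound 1 differs from compound 3 elsewhere as well, so what the two numbers show cannot be carried over directly. Compound 3 is expected to sit above compound 2, with a step in this assay of a 5.2-fold higher number from compound 2 to compound 3 (0.72 log units; beyond the scatter), a loss that is probably beyond the scatter but far smaller than the gap between compound 2 and compound 1. For compound 3 the estimated value in this assay is 150 nM, in a range from 40 nM to 600 nM.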

Compound 3, inhibition constant: 663 nM
Compound 3: the middle estimate sits 4.4-fold (0.65 log units) below what was measured, and the stated range ends below it.
By their numbers in this assay, from the lowest: compound 2; then compounds 3 and 1 (each within the scatter of the next).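

In this assay a single methyl in place of hydrogen on the saturated chain carbon bound to an amide-type nitrogen, an aromatic carbon and a saturated chain carbon gives a 23-fold higher number from compound 2 to compound 3 (1.37 log units; beyond the scatter) and thus a large loss from this one change, which compounds 1 and 2 could not show because they differ in more than one place. With that methyl present, methoxy in place of fluoro on an aromatic carbon gives a 1.5-fold lower number from compound 1 to compound 3 (0.17 log units; within the scatter) and so no readable difference, which places the gap between compound 1 and compound 2 largely with the added methyl in this series. Nothing measured here speaks to why this methyl carries such a loss.

The compounds shown leave open whether the loss follows from the added carbon alone or would also appear with an ethyl group, a cyclopropane ring closed on this carbon or a hydroxyl group at the same place. They also leave open whether fluoro in place of methoxy would be equally silent in compound 2, which lacks the added methyl.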